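Swapping a pyridine amide for a pyrazole amide

The compounds below may be only part of what the source reports. "The series", "measured", "known", "first", "only" and "open" are said of these compounds alone.

Compound 1 `O=C(NC1CCC(=Cc2cccc(Oc3ccc(C(F)(F)F)cn3)c2)CC1)c1cccnc1` inhibits an assay for inhibition of Fatty-acid amide hydrolase 1 (Rattus norvegicus), read by fluorescence, with stated times of 1 min and 50 min (on this read-out lower numbers stand for stronger inhibition and higher numbers for weaker inhibition), with a half-maximal inhibitory concentration of 27.8 nM. Compound 2 `O=C(NC1CCC(=Cc2cccc(Oc3ccc(C(F)(F)F)cn3)c2)CC1)c1ccccn1` shares the same core but carries a different ring on the carbonyl carbon; in this assay compound 2 has "not determined" (no result reported), so there is no number to stand on. Compound 3 `O=C(NC1CCC(=Cc2cccc(Oc3ccc(C(F)(F)F)cn3)c2)CC1)c1cc[nH]n1` differs from compound 2 by 1H-pyrazol-3-yl in place of pyridin-2-yl on a carbonyl carbon. Among the compounds with values here, with no measured step to lean on, the expected change is small, within the usual scatter or a modest loss. Compound 3 is therefore estimated at 45 nM, with a plausible range from 8 nM to 250 nM.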

Compound 3, half-maximal inhibitory concentration: 266 nM
Beside the measured number, compound 3's estimate is 5.9-fold (0.77 log units) below it, outside the stated range (above it).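

The ring on the carbonyl carbon matters in this assay: with 1H-pyrazol-3-yl in place of pyridin-3-yl, the data show a clear loss of inhibition (a 9.6-fold higher number from compound 1 to compound 3 (0.98 log units; beyond the scatter)). Within the data shown here, this is the first readable change at this position, and it lies beyond the usual scatter. Nothing available explains the loss.

The step from compound 2 to compound 3 cannot be read, so the comparison with pyridin-2-yl stays unsettled. On these data alone, it also remains open how a plain phenyl ring or a thiophene ring would fare on this carbonyl carbon.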